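Growth inhibition series

The source may report more compounds than this note shows. Statements on the series, on what has been measured and on what is new or still open speak of the compounds shown alone.

Measured compounds:
Compound 1 `COc1cc(/C=C/C(=O)c2cccc(-n3cc(-c4ccc(Cl)cc4)[nH]c3=O)c2)cc(OC)c1OC`: 7380 nM
Compound 2 `COc1ccc(-c2cn(-c3cccc(C(=O)/C=C/c4cc(OC)c(OC)c(OC)c4)c3)c(=O)[nH]2)cc1`: 1840 nM

In a functional assay on COLO 205 cells (Homo sapiens) for inhibition (on this read-out higher numbers stand for weaker inhibition of growth and lower numbers for stronger inhibition of growth), compound 2 gives the lowest of the two numbers; its nearest neighbour is compound 1, a step of a 4.0-fold lower number from compound 1 to compound 2 (0.60 log units; beyond the scatter). Compound 3 `COc1cc(/C=C/C(=O)c2cccc(-n3cc(-c4cc(OC)c(OC)c(OC)c4)[nH]c3=O)c2)cc(OC)c1OC` is not yet measured. Its change from compound 2 is 3,4,5-trimethoxyphenyl in place of 4-methoxyphenyl on an aromatic carbon. Among the measured compounds shown here, no measured step alters this same ring; the only step in hand, a 4.0-fold lower number from compound 1 to compound 2 (0.60 log units; beyond the scatter), concerns a different exchange on that ring and bears on it only loosely. A change within the scatter is therefore expected, a 1.2-fold lower number from compound 2 to compound 3 (0.09 log units; within the scatter). Compound 3 is estimated at 1500 nM, between 400 nM and 6000 nM.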

Compound 3, concentration for 50% growth inhibition: 1520 nM
Estimate against measurement, compound 3: 1.0-fold (0.01 log units) below; low and high end bracket the measured number.
By their numbers in this assay, from the lowest: compounds 3 and 2 (each within the scatter of the next); then compound 1.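

In this assay, 3,4,5-trimethoxyphenyl in place of 4-methoxyphenyl gives a 1.2-fold lower number from compound 2 to compound 3 (0.08 log units; within the scatter), so the larger group at this aromatic carbon leaves the read-out within the scatter. Against 4-chlorophenyl, the same group gives a 4.9-fold lower number from compound 1 to compound 3 (0.69 log units; beyond the scatter), which places both methoxy-bearing groups apart from the chloro one. No supporting data explain these differences.

Open, from the compounds shown here alone, is whether the read-out stays level with an unsubstituted phenyl, a 4-hydroxyphenyl or a 4-(dimethylamino)phenyl group at this carbon. Also open, going by these compounds, is whether a 3-methoxyphenyl group would match 4-methoxyphenyl.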